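Compound 1 to Compound 4: Nitro Takes the Place of Methyl

The compounds below may be only part of what the source reports. "The series", "measured", "known", "first", "only" and "open" are said of these compounds alone.

Compound 1 `COc1cc(-c2nnc3n2NC(c2ccco2)C(C(=O)c2ccc(C)cc2)S3)cc(OC)c1OC` is the starting point of this comparison. In a functional assay on A549 cells (Homo sapiens) for cytotoxicity, read by MTT assay, with a stated time of 48 h (on this read-out lower numbers stand for stronger inhibition and higher numbers for weaker inhibition), compound 1 is reported only as a limit, > 100000 nM, and not as a number; this is the limit of > 100000 nM in this assay, at which 1 of the 3 values shown sits. Two close relatives do carry numbers. Compound 2 `COc1cc(-c2nnc3n2NC(c2ccco2)C(C(=O)c2ccccc2F)S3)cc(OC)c1OC` gives 78700 nM in this assay, and compound 3 `COc1cc(-c2nnc3n2NC(c2ccco2)C(C(=O)c2ccccc2C)S3)cc(OC)c1OC` gives 80000 nM in this assay. The change an at least 1.2-fold lower number from compound 1 to compound 2 (0.10 log units; that floor lies within the scatter) and the change an at least 1.2-fold lower number from compound 1 to compound 3 (0.09 log units; that floor lies within the scatter) are therefore both small, and the difference a 1.0-fold higher number from compound 2 to compound 3 (0.01 log units; within the scatter) shows that exchanging fluoro for methyl on that ring left the number essentially where it was.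

Compound 4 `COc1cc(-c2nnc3n2NC(c2ccco2)C(C(=O)c2ccc([N+](=O)[O-])cc2)S3)cc(OC)c1OC` differs from compound 1 by nitro in place of methyl on an aromatic carbon. Going by the values given here, no measured step touches the group at this place; the two measured steps alter the ring elsewhere and shift the number only slightly, so they bear on the new step only as a sign that this ring tolerates small changes without much movement. Compound 4 is accordingly expected to remain weak in this assay, with a step of an at least 1.2-fold lower number from compound 1 to compound 4 (0.09 log units; that floor lies within the scatter) that stays within the scatter. The estimate for compound 4 is 80000 nM, expected to lie between 30000 nM and 200000 nM, with a real chance that only a limit is reported again.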

Compound 4, half-maximal inhibitory concentration: > 100000 nM
Compound 4: only a limit was reported; the forecaster's own chance of this, stated with the estimate: 40%; middle value at least 1.2-fold (0.09 log units) from the limit.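

Exchanging methyl for nitro on this carbon of the ring left compound 4 at a limit of this assay and not at a number, the same limit that compound 1 carries, so the step between these two compounds cannot be read, and that limit now holds a larger share of the series: the limit of > 100000 nM in this assay, at which 2 of the 4 values shown sit. Against the two relatives that carry numbers, the result is an at least 1.2-fold higher number from compound 3 to compound 4 (0.09 log units; that floor lies within the scatter) and an at least 1.2-fold higher number from compound 2 to compound 4 (0.10 log units; that floor lies within the scatter), and neither floor separates the compounds from one another. Methyl and nitro on this carbon thus both end at a limit, which shows no readable gain from the change, though the limit hides how far apart the two compounds really stand.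

The compounds shown leave open whether any group on this carbon, such as an amine or a carboxylic acid, would bring a number clearly under the limit. Also open, from the compounds shown here alone, is whether nitro on another carbon of this ring would behave as the 2-fluorophenyl and 2-methylphenyl groups do, and whether a change on the shared core would do more than any step seen here.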